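This account rests on a few compounds, and the source may have more. Where it says the series, first, only, none or still open, it means among the compounds named here.

- compound 1 `CCSc1nnc(-c2cc(OC)c(OC)c(OC)c2)n1-c1ccc(OC)cc1`: > 60000 nM, a limit of the assay and not a number
- compound 2 `COc1ccc(-n2c(SCc3ccccc3)nnc2-c2cc(OC)c(OC)c(OC)c2)cc1`: 42400 nM
- compound 3 `COc1cc(-c2nnc(SCc3ccccc3)n2-c2ccc(N(C)C)cc2)cc(OC)c1OC`: 54000 nM

In a functional assay on HCT-116 cells (Homo sapiens) for inhibition, read by MTT assay, with a stated time of 48 h (on this read-out lower numbers stand for stronger inhibition and higher numbers for weaker inhibition), compound 3 gives 54000 nM, which lies within the scatter of compound 2 at 42400 nM.

The next compound, compound 4 `COc1ccc(C(=O)CSc2nnc(-c3cc(OC)c(OC)c(OC)c3)n2-c2ccc(N(C)C)cc2)cc1O`, keeps the core and the dimethylamino group of compound 3. The change is (3-hydroxy-4-methoxyphenyl)carbonyl in place of phenyl on a saturated chain carbon bound to a sulfur: in words, (3-hydroxy-4-methoxyphenyl)carbonyl in place of phenyl on a saturated chain carbon bound to a sulfur.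

Going by the values given here, two measured steps bear on this. At that same place, phenyl in place of methyl gave an at least 1.4-fold lower number from compound 1 to compound 2 (0.15 log units; that floor lies within the scatter). On an aromatic carbon, dimethylamino in place of methoxy gave a 1.3-fold higher number from compound 2 to compound 3 (0.11 log units; within the scatter). Neither step goes beyond the scatter, so neither sets a size for this much larger change.

Compound 3, at 54000 nM, has little room left upward, so a lower number is the expected direction. The expected change is a 27-fold lower number from compound 3 to compound 4 (1.43 log units; beyond the scatter). For compound 4 the estimated value is 2000 nM, with an expected range from 150 nM to 30000 nM.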

Compound 4, half-maximal inhibitory concentration: > 100000 nM
Compound 4 gave a limit, no number; the forecaster's own chance of this, stated with the estimate: 8%; at least 50-fold (1.69 log units) between middle value and limit.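

Compound 4 reads in this assay as a limit of the assay and not a number: the limit of > 100000 nM in this assay, at which 1 of the 4 values shown sits.

Until now this place had held only methyl and phenyl, and the step between them stayed within the scatter. Going by these compounds, putting the much larger (3-hydroxy-4-methoxyphenyl)carbonyl group there gave an at least 1.8-fold higher number from compound 3 to compound 4 (0.26 log units; that floor lies within the scatter), so adding a carbonyl and a ring bearing hydroxy and methoxy brought no lower number, and the true size of the change stays unknown.

The compounds shown leave open whether a carboxylic acid or an amine on a saturated chain at this place would give a lower number. They also leave open whether the same (3-hydroxy-4-methoxyphenyl)carbonyl group would read any differently with methoxy in place of dimethylamino on the aromatic carbon.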